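The source may report more compounds than this note shows. Statements on the series, on what has been measured and on what is new or still open speak of the compounds shown alone.

Measured so far:
- compound 1, `CCCCc1ccc(NC(=O)N[C@H](C)c2ccccc2)cc1`: 28%
- compound 2, `CCCCCc1ccc(NC(=O)N[C@H](C)c2ccccc2)cc1`: 97%
- compound 3, `CCCCCc1ccc(NC(=O)N[C@@H](C)c2ccccc2)cc1`: 93%

In an ADME assay on the whole organism with Oryza sativa as the target, tested at 10 uM (a higher number here means a weaker effect of the compound at the concentration tested, a lower number a stronger effect), compound 2 gives 97%, the highest of the three numbers. Compound 3 lies nearest, a number 4 percentage points lower from compound 2 to compound 3 (within the scatter), so the two are indistinguishable; the only separation between them is the fact that compounds 2 and 3 differ only in the configuration as drawn. Compound 1 lies furthest, a number 69 percentage points higher from compound 1 to compound 2 (beyond the scatter), a single chain carbon being the whole of that structural difference.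

The next compound, compound 4, `CC(=O)c1ccc(NC(=O)N[C@H](C)c2ccccc2)cc1`, is not yet measured. Against compound 2 the change is acetyl in place of pentyl on an aromatic carbon. Among the compounds with values here, the step that bears on it is the one from compound 1 to compound 2: a one-carbon lengthening of the chain moved this assay by a large margin, so the read-out is evidently sensitive to what sits on this aromatic carbon. Within the data shown here, compound 4 carries a group shorter than either the butyl of compound 1 or the pentyl of compound 2, and of a different kind; the step from compound 2 to compound 4 is therefore expected to be large and downward, a number 72 percentage points lower from compound 2 to compound 4 (beyond the scatter), with wide uncertainty since no acetyl analogue has been measured. For compound 4 the expected value in this assay is 25%, within 5% to 60%.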

Compound 4, a percentage reported as activity, at one concentration (the size of the read-out at that concentration, not a potency): 84%
Estimate against measurement, compound 4: 59 percentage points below; the whole stated range lies below it.
By their numbers in this assay, from the lowest: compound 1; then compounds 4, 3 and 2 (each within the scatter of the next, the first and the last beyond it).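

In this assay, acetyl in place of pentyl gives a number 13 percentage points lower from compound 2 to compound 4 (beyond the scatter), a modest step, while acetyl in place of butyl gives a number 56 percentage points higher from compound 1 to compound 4 (beyond the scatter), a large one. The read-out at this aromatic carbon, para to a large group, therefore does not simply follow the size of the group: acetyl, with 3 heavy atoms and a hydrogen-bond acceptor, stands much nearer to pentyl, with 5 heavy atoms and no acceptor, than to butyl, and among the compounds shown only compound 1, the butyl compound, carries a low number. Nothing measured on these compounds accounts for either step.

On these data alone, whether the low number of compound 1 belongs to butyl alone, or extends to a propyl or ethyl chain, stays open, as does the reading of a hexyl chain at the same place. Also open, as far as these compounds go, is how an amine, a carboxylic acid or a methoxy group on this aromatic carbon would read in this assay, and whether the mirror-image configuration of the acetyl compound would read the same.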